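This account rests on a few compounds, and the source may have more. Where it says the series, first, only, none or still open, it means among the compounds named here.

Of the compounds shown here, two with a shared core have so far been tested in a functional assay on HepG2 cells (Homo sapiens) for cytotoxicity, read by MTT assay, with a stated time of 48 h; a higher number here means a weaker inhibitor, a lower number a stronger inhibitor. Compound 1 `CCCCCCCCNC(=O)[C@@H](NC(=O)c1cccs1)[C@@H](C)O` gives 149000 nM in this assay. Compound 2 `CCCCCCCCCCCCNC(=O)[C@@H](NC(=O)c1ccco1)[C@@H](C)O` gives 147000 nM in this assay, which lies within the usual scatter of the value of compound 1, so the two cannot be told apart on these numbers. Compound 3 `CCCCCCCCCCCCNC(=O)[C@@H](NC(=O)c1cccs1)[C@@H](C)O` has not yet been measured. It differs from compound 2 in one place: thiophen-2-yl in place of furan-2-yl on a carbonyl carbon. Among the compounds with values here, no step between two measured compounds that differ in exactly this way is available, so the size of this change cannot be read off directly. Since compound 1 already carries the thiophen-2-yl group and gives 149000 nM, a step no larger than the scatter is expected from compound 2 to compound 3, that is a 1.0-fold higher number from compound 2 to compound 3 (0.00 log units; within the scatter). Compound 3 is therefore estimated to give about 148000 nM, expected to fall between 75000 nM and 300000 nM.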

Compound 3, half-maximal inhibitory concentration: 30100 nM
Estimate against measurement, compound 3: 4.9-fold (0.69 log units) above, and the stated range ends above it.
By their numbers in this assay, from the lowest: compound 3; then compounds 2 and 1 (each within the scatter of the next).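

In this assay, the group on the carbonyl carbon makes a real difference: thiophen-2-yl in place of furan-2-yl gives a 4.9-fold lower number from compound 2 to compound 3 (0.69 log units; beyond the scatter), even though the two rings have the same heavy-atom count. The chain matters too, as butyl in place of hydrogen on a saturated chain carbon, eight bonds along the chain from an amide-type nitrogen, gives a 5.0-fold lower number from compound 1 to compound 3 (0.69 log units; beyond the scatter), and neither change could be read from the first two compounds alone, which differ in two places. No measurement at hand explains either step.

As far as these compounds go, it remains open whether the chain step would be the same size with furan-2-yl on the carbonyl carbon. From the compounds shown here alone, it is also open how a still longer chain, or a phenyl ring on that carbonyl carbon, would compare.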